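The compounds below may be only part of what the source reports. "The series", "measured", "known", "first", "only" and "open" are said of these compounds alone.

Within the data shown here, compound 2 `CCc1nnsc1CO/N=C/c1c(C)nn(C)c1Oc1ccccc1Cl` is the only compound here with a measured number: in a functional assay on SGC-7901 cells (Homo sapiens) for inhibition, read by MTT assay, with a stated time of 48 h (a lower number here means a stronger inhibitor, a higher number a weaker inhibitor), compound 2 gives 15800 nM. Compound 1 `Cc1nnsc1CO/N=C/c1c(C)nn(C)c1Oc1ccccc1Cl` gives only a limit of the assay, namely > 50000 nM in this assay. Compound 3 `CCCc1nnsc1CO/N=C/c1c(C)nn(C)c1Oc1ccccc1Cl` differs from compound 2 by methyl in place of hydrogen on a saturated chain carbon, two bonds along the chain from an aromatic carbon. Among the measured compounds shown here, the single measured step is of the same kind and lowered the number: an at least 3.1-fold lower number from compound 1 to compound 2 (0.50 log units; beyond the scatter). On that thin basis a further, smaller drop is expected, a 2.0-fold lower number from compound 2 to compound 3 (0.30 log units; within the scatter), with wide uncertainty. Compound 3 is therefore estimated to give about 8000 nM, between 2500 nM and 25000 nM.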

Compound 3, half-maximal inhibitory concentration: 17600 nM
Beside the measured number, compound 3's estimate is 2.2-fold (0.34 log units) below it, and the stated range covers the measured number.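

Going from ethyl to propyl on the 1,2,3-thiadiazole changes nothing that can be read: there is a 1.1-fold higher number from compound 2 to compound 3 (0.05 log units; within the scatter), so the fall seen with the first added carbon does not carry on with the second. Propyl still compares well with the methyl compound, with an at least 2.8-fold lower number from compound 1 to compound 3 (0.45 log units; beyond the scatter). That comparison rests on a limit for compound 1: the limit of > 50000 nM in this assay, at which 1 of the 3 values shown sits.

Still open, on these data alone, is whether a longer chain such as butyl, a branched group such as isopropyl, or a small ring such as cyclopropyl would give a lower number at this place.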